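Flipping two stereocentres: does cytotoxicity depend on shape?

The source may report more compounds than this note shows. Statements on the series, on what has been measured and on what is new or still open speak of the compounds shown alone.

In a functional assay on L1210 cells (Mus musculus) for cytotoxicity (on this read-out higher numbers stand for weaker inhibition and lower numbers for stronger inhibition), compound 3 `CCCCCCCCCCCCCC[C@@H]1N[C@@H](CO)[C@@H]1O` gives 4.5 ug/mL. That matches compound 1 `CCCCCCCCCCCCCC[C@H]1N[C@H](CO)[C@H]1O` at 4.5 ug/mL, and compound 2 `CC(C)CC[C@H](O)CCCCCCCCC[C@@H]1N[C@@H](CO)[C@@H]1O`, at 2.9 ug/mL, lies within the scatter of both. The next candidate, compound 4 `CCCCCCCCCCCCCC[C@@H]1N[C@H](CO)[C@H]1O`, keeps every atom and bond of compound 3 and alters only the three-dimensional arrangement: the two compounds have the same atoms and bonds and differ only in configuration as drawn: 2 of 3 stereo elements differ; a stereocentre at a saturated ring carbon is drawn S in compound 3 and R in compound 4; a stereocentre at a saturated ring carbon is drawn R in compound 3 and S in compound 4. The nearest guide is no change at the digits printed from compound 1 to compound 3 (within the scatter), seen alongside (the fact that compounds 1 and 3 differ only in the configuration as drawn). In that pair all stereocentres are inverted, giving mirror images, and this assay did not separate them. The other measured step, a 1.6-fold higher number from compound 2 to compound 3 (0.19 log units; within the scatter), alters the chain rather than the configuration, so it says little here. Among the measured compounds shown here, no measured pair shows what inverting only some of the stereocentres does, so this forecast is uncertain. The expected result is no change at the digits printed from compound 3 to compound 4 (within the scatter), with no direction favoured and nothing beyond the scatter anticipated. For compound 4 the estimate is 4.5 ug/mL, with an expected range from 2 ug/mL to 10 ug/mL.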

Compound 4, half-maximal inhibitory concentration: 4.5 ug/mL
For compound 4 middle estimate and measured number coincide at the digits printed, within the range that was stated.
By their numbers in this assay, from the lowest: compounds 2, 1, 3 and 4 (each within the scatter of the next).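

Inverting only some of the stereocentres, a change the mirror-image pair could not test, leaves the number in this assay where it was: the step is no change at the digits printed from compound 3 to compound 4 (within the scatter) for two ring carbons drawn differently, and no change at the digits printed from compound 1 to compound 4 (within the scatter) for one. Compounds 1, 3 and 4 therefore show no link between drawn configuration and this read-out, a finding that applies to these three compounds only. The comparison can be read directly because nothing but configuration separates the compounds: the fact that compounds 3 and 4 differ only in the configuration as drawn

As far as these compounds go, whether configuration would start to matter with a shorter chain, a longer chain, or an acetyl group on the nitrogen of the shared core remains open. The compounds shown also cannot say whether the other arrangements of the ring stereocentres would behave the same way.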